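Swapping the aryl group on the carbonyl of compound 3

The source may report more compounds than this note shows. Statements on the series, on what has been measured and on what is new or still open speak of the compounds shown alone.

The series shares a core that carries an amino group and a ketone; the compounds differ in the group attached to the carbonyl carbon. In a functional assay on WI-38 VA13 cells (Homo sapiens) for cytotoxicity (on this read-out lower numbers stand for an effect already at smaller amounts and higher numbers for an effect only at larger amounts of compound), compound 1 `COc1ccccc1C(=O)c1sc2nc(-c3cccs3)ccc2c1N` gives 0.059 ug/mL. Compound 2 `CC(C)(C)C(=O)c1sc2nc(-c3cccs3)ccc2c1N` gives 0.57 ug/mL in this assay, and compound 3 `Nc1c(C(=O)c2cccc(Br)c2)sc2nc(-c3cccs3)ccc12` gives 0.5 ug/mL. Among these three numbers compound 3 stands second highest; its nearest neighbour is compound 2, with a 1.1-fold lower number from compound 2 to compound 3 (0.06 log units; within the scatter), while the step of an 8.5-fold higher number from compound 1 to compound 3 (0.93 log units; beyond the scatter) is beyond the scatter.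

Compound 4 `Nc1c(C(=O)c2ccc(F)cc2F)sc2nc(-c3cccs3)ccc12` differs from compound 3 in one place: 2,4-difluorophenyl in place of 3-bromophenyl on a carbonyl carbon. Within the data shown here, two measured steps bear on this exchange, both swaps of the group on the carbonyl carbon. a 9.7-fold higher number from compound 1 to compound 2 (0.99 log units; beyond the scatter) and an 8.5-fold higher number from compound 1 to compound 3 (0.93 log units; beyond the scatter) were modest, and a 1.1-fold lower number from compound 2 to compound 3 (0.06 log units; within the scatter) stayed within the scatter. Among the measured compounds shown here, no measured pair swaps one substituted phenyl for another with compound 3 as the starting point, so the direction is uncertain; since compound 1 with its 2-methoxyphenyl gave 0.059 ug/mL, a lower number than that of compound 3 looks somewhat more likely than a higher one, but a modest step either way is expected. For compound 4 a value of 0.3 ug/mL is estimated, with a range from 0.06 ug/mL to 1.5 ug/mL, which would mean an expected step of a 1.7-fold lower number from compound 3 to compound 4 (0.22 log units; within the scatter).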

Compound 4, half-maximal effective concentration: 2.3 ug/mL
Compound 4: the middle estimate sits 7.7-fold (0.88 log units) below what was measured; measured number outside the range, above it.
By their numbers in this assay, from the lowest: compound 1; then compounds 3 and 2 (each within the scatter of the next); then compound 4.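

The swap shows that one substituted phenyl cannot simply stand in for another on this carbonyl carbon: in this assay the exchange of 3-bromophenyl for 2,4-difluorophenyl gives a 4.6-fold higher number from compound 3 to compound 4 (0.66 log units; beyond the scatter) and so lies beyond the scatter, whereas the earlier exchange of tert-butyl for 3-bromophenyl did not. The 2,4-difluorophenyl group also separates from tert-butyl, with a 4.0-fold higher number from compound 2 to compound 4 (0.61 log units; beyond the scatter) in this read-out, so the position now tells these groups apart more finely than the first three compounds could show. Among these compounds, the widest gap, a 39-fold higher number from compound 1 to compound 4 (1.59 log units; beyond the scatter) and the only large step here, lies between two substituted phenyl groups, so a phenyl ring on the carbonyl carbon does not by itself set the number, and nothing available accounts for these differences.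

The compounds shown leave open whether a phenyl carrying a single fluorine would sit nearer compound 3 or compound 4, and so whether one fluorine or both go with the higher number. They also leave open how this position would respond to a phenyl ring carrying an amine or a carboxylic acid.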